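Trifluoromethyl for hydroxy, starting from an assay limit

The source may hold more compounds than are shown below. What is called first, only, known or untested is meant among the compounds shown, and "the series" means these compounds.

In a functional assay on HT-29 cells (Homo sapiens) for antiproliferative activity, read by MTT assay, with a stated time of 72 h, tested at 20 uM (a higher number here means a weaker inhibitor, a lower number a stronger inhibitor), compound 1 (`CN1CCN(C(=S)SCc2ccc3nc(N)nc(N)c3c2)CC1`) gives > 20000 nM, which is a limit and not a number. From the compounds shown here alone, compound 2 (`Nc1nc(N)c2cc(CSC(=S)N3CCN(c4ccc(O)cc4)CC3)ccc2n1`) gives > 20000 nM, again only a limit, so its true position is unknown. Going by the values given here, the only measured step, a step that the two limits leave unreadable from compound 1 to compound 2, has no readable size, and the limit of > 20000 nM in this assay, at which 2 of the 2 values shown sit, is all the evidence available. Compound 3 (`Nc1nc(N)c2cc(CSC(=S)N3CCN(c4ccc(C(F)(F)F)cc4)CC3)ccc2n1`) carries trifluoromethyl in place of hydroxy on an aromatic carbon. The expected step is a number no higher from compound 2 to compound 3 (the limit leaves the size open), an estimate with no firm direction. For compound 3 the estimated value is 20000 nM, with an expected range of 6000 nM to 40000 nM.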

Compound 3, half-maximal inhibitory concentration: > 20000 nM
Compound 3 gave a limit, no number (the forecaster's own chance of this, stated with the estimate: 65%); the middle value sits exactly at the limit.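

Going by these compounds alone, compound 3, like compound 1 and compound 2, gives only a limit and not a number in this assay, so no step among them can be read. The compounds shown leave open where each truly sits, and whether trifluoromethyl in place of hydroxy changes anything: the limit of > 20000 nM in this assay, at which 3 of the 3 values shown sit.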